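Moving the same aryl substituent within a benzoxazinone series

The source may hold more compounds than are shown below. What is called first, only, known or untested is meant among the compounds shown, and "the series" means these compounds.

Compound 2 `CC1CCCC(C)N1CCCCCN1C(=O)C(c2cccc(C(=N)NO)c2)Oc2ccccc21` is the reference here. In an assay on isolated protein for inhibition of serine protease 1 (Homo sapiens), tested at 100 uM (on this read-out higher numbers stand for more inhibition at the one concentration tested (going by the name of the read-out) and lower numbers for less inhibition), compound 2 gives 21%. Among the compounds with values here, its only measured neighbour is compound 1 `CC1CCCC(C)N1CCCCCN1C(=O)C(c2ccc(Cl)c(Cl)c2)Oc2ccccc21`, which in this assay gives 14%; the difference, a number 7 percentage points higher from compound 1 to compound 2 (within the scatter), lies within the usual scatter, so the two numbers cannot be ranked against each other. Compound 3 `CC1CCCC(C)N1CCCCCN1C(=O)C(c2ccc(C(=N)NO)cc2)Oc2ccccc21` carries the same atoms as compound 2, joined differently: a group of 10 heavy atoms (7 carbon, 2 nitrogen, 1 oxygen; one six-membered aromatic ring of carbon only) in place of a group of 10 heavy atoms (7 carbon, 2 nitrogen, 1 oxygen; one six-membered aromatic ring of carbon only), on a saturated ring carbon. Within the data shown here, no measured step exchanges one such group for the other on a saturated ring carbon; the single step known, a number 7 percentage points higher from compound 1 to compound 2 (within the scatter), concerns a different exchange and was itself within the scatter. Nothing in the data therefore points to a shift beyond the scatter, and compound 3 is expected to land near compound 2, with no change at the digits printed from compound 2 to compound 3 (within the scatter) as the anticipated step. The estimate for compound 3 in this assay is 21%, between 8% and 36%.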

Compound 3, a percentage reported as inhibition, at one concentration (the size of the read-out at that concentration, not a potency): 8%
Compound 3: the middle estimate sits 13 percentage points above what was measured; low and high end bracket the measured number.
By their numbers in this assay, from the lowest: compounds 3, 1 and 2 (each within the scatter of the next, the first and the last beyond it).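

At the saturated ring carbon next to the ring oxygen, this assay is sensitive to how the atoms of the group are joined, and not only to which atoms it holds: the group that enters has the same atoms and the same counts of donors and acceptors as the group that leaves, yet the result is a number 13 percentage points lower from compound 2 to compound 3 (beyond the scatter). The exchange of the chlorine-bearing group for the new one gives a number 6 percentage points lower from compound 1 to compound 3 (within the scatter), so this exchange, like the earlier one, allows no ranking. No measurement shown here accounts for the effect of the rearrangement.

The compounds shown leave open whether a nitrile or a carboxylic acid, joined in the same two ways, would give the same step. They also leave open whether that step would survive a shorter chain on the ring nitrogen.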